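Aryl swap on the double-bonded chain carbon, pyridine to furan

A few compounds are considered here, and "the series" means these few. Any claim that something is new, unique, unknown or untested is made for them only; others in the source may bear on it.

The two measured compounds share a core and differ in the group on the double-bonded chain carbon bound to a double-bonded ring carbon. Compound 1 `COc1cc(/C=C2\SC(=O)N(Cc3ccc(C(=O)O)cc3)C2=O)cc(OC)c1OC` carries a trimethoxyphenyl group there; in a functional assay on A549 cells (Homo sapiens) for cytotoxicity, read by MTT assay, with a stated time of 24 h (a higher number here means a weaker inhibitor, a lower number a stronger inhibitor), compound 1 gives 36000 nM. Compound 2 `O=C(O)c1ccc(CN2C(=O)S/C(=C\c3ccccn3)C2=O)cc1` carries a pyridin-2-yl group; in this assay compound 2 gives 80000 nM. Among the two numbers measured, compound 2 stands highest, and its gap to compound 1 lies beyond the scatter, so compound 2 is the weaker of the pair.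

Compound 3 `O=C(O)c1ccc(CN2C(=O)S/C(=C\c3ccco3)C2=O)cc1` differs from compound 2 in one place: furan-2-yl in place of pyridin-2-yl on a double-bonded chain carbon bound to a double-bonded ring carbon. Among the measured compounds shown here, no step of this kind between measured compounds exists, so nothing measured points in either direction for this change. The step of a 1.1-fold lower number from compound 2 to compound 3 (0.06 log units; within the scatter) is therefore expected to stay within the usual scatter, with no real change beyond it. Compound 3 is expected to give 70000 nM in this assay, in the range 30000 nM to 160000 nM.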

Compound 3, half-maximal inhibitory concentration: 76000 nM
Compound 3: middle estimate off by 1.1-fold (0.04 log units), on the low side; the range from low to high includes it.
By their numbers in this assay, from the lowest: compound 1; then compounds 3 and 2 (each within the scatter of the next).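

In this assay, furan-2-yl in place of pyridin-2-yl on a double-bonded chain carbon bound to a double-bonded ring carbon gives a 1.1-fold lower number from compound 2 to compound 3 (0.02 log units; within the scatter). Among the compounds shown here, this is the first step that changes only this position, and it shows that replacing a six-membered aromatic ring with 1 hetero atom by a five-membered aromatic ring with 1 hetero atom, with nitrogen giving way to oxygen, leaves the reading unchanged within the scatter for this pair. Nothing measured here accounts for this agreement between the two rings.

The compounds shown leave open whether this agreement extends to other rings at this position, such as a plain phenyl, a thiophen-2-yl or a pyridin-3-yl group, and which part of the trimethoxyphenyl group of compound 1 goes with its printed value of 36000 nM. Also open, from the compounds shown here alone, is how a single methoxy group, or an amine on the furan ring of compound 3, would read in this assay.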